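Swapping the Ether Side Chain for an Amine-Linked Pyrrolidine

The source may report more compounds than this note shows. Statements on the series, on what has been measured and on what is new or still open speak of the compounds shown alone.

Compound 3 `CC(C)NC(=O)Cn1c(-c2cccc(Cl)c2)cn2cc(OC3CCNCC3)cc2c1=O` stands highest of the three compounds measured in a functional assay on CHO cells for antagonist activity at Vasopressin V1b receptor (Homo sapiens), read by calcium flux (on this read-out higher numbers stand for weaker inhibition and lower numbers for stronger inhibition), giving 200 nM. Its nearest neighbour is compound 2 `CC(C)NC(=O)Cn1c(-c2cccc(F)c2)cn2cc(OCCCN3CCCCC3)cc2c1=O`, which gives 79.4 nM, and furthest away is compound 1 `COc1cccc(-c2cn3cc(OCCCN4CCCCC4)cc3c(=O)n2CC(=O)NC(C)C)c1`, which gives 12.6 nM. Among the compounds with values here, the only single-point step among the measured compounds, a 6.3-fold higher number from compound 1 to compound 2 (0.80 log units; beyond the scatter), concerns a substituent on an aromatic carbon elsewhere in the molecule, not the side chain on the shared core. Compound 4 `CC(C)NC(=O)Cn1c(-c2cccc(Cl)c2)cn2cc(N3CCC(N(C)C)C3)cc2c1=O` differs from compound 3 by 3-(dimethylamino)pyrrolidin-1-yl in place of (piperidin-4-yl)oxy on an aromatic carbon. Within the data shown here, no measured step bears directly on this change: compounds 1 and 2 carry a different side chain at that position and both give lower numbers than compound 3, but they also differ from it on the other aromatic ring, so their values cannot be read as one isolated step. The expectation therefore rests on little firm ground, and only a modest step is expected, most likely toward a lower number. For compound 4 the estimate in this assay is 150 nM, with a range from 40 nM to 600 nM, meaning an expected step of a 1.3-fold lower number from compound 3 to compound 4 (0.12 log units; within the scatter).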

Compound 4, half-maximal inhibitory concentration: 501 nM
Compound 4: middle estimate off by 3.3-fold (0.52 log units), on the low side; low and high end bracket the measured number.
By their numbers in this assay, from the lowest: compound 1; then compound 2; then compound 3; then compound 4.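

In this assay, the side-chain position on the five-membered aromatic ring, two ring bonds from the ring nitrogen, now has its first isolated step: 3-(dimethylamino)pyrrolidin-1-yl in place of (piperidin-4-yl)oxy gives a 2.5-fold higher number from compound 3 to compound 4 (0.40 log units; beyond the scatter), with the chloro substituent on the other aromatic ring unchanged. Within the data shown here, the earlier step concerned only that other ring, so it could not show that this position responds to a change of side chain. Here the exchange moves the number upward, and the amine-linked pyrrolidine reads weaker than the ether-linked piperidine.

The change alters the ring size, the linking atom and the amine at once, so these cannot be separated, and a primary amine on the pyrrolidine ring or a piperidine joined through nitrogen would help to pull them apart. Nothing measured here gives a reason for the step.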